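A few compounds are considered here, and "the series" means these few. Any claim that something is new, unique, unknown or untested is made for them only; others in the source may bear on it.

Three compounds have been measured in an assay for binding affinity to Alpha-1A adrenergic receptor (Homo sapiens), read by radioligand binding; a higher number here means a weaker inhibitor, a lower number a stronger inhibitor:

Compound 1, `CS(=O)(=O)c1ccc(F)cc1NCC1=NCCN1`: 813 nM
Compound 2, `CS(=O)(=O)c1cc(F)ccc1NCC1=NCCN1`: 661 nM
Compound 3, `CS(=O)(=O)c1ccc(Cl)cc1NCC1=NCCN1`: 537 nM

Among the compounds with values here, compound 1 and compound 3 share one core; the only change between them is chloro in place of fluoro on an aromatic carbon, and it gave a 1.5-fold lower number from compound 1 to compound 3 (0.18 log units; within the scatter). Compound 2 has the same atoms as compound 1 joined differently; the difference between the two cores is not broken down here. Compound 2 and compound 1 give numbers within the scatter of each other, as do compound 2 and compound 3.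

Compound 4, `CS(=O)(=O)c1cc(Cl)ccc1NCC1=NCCN1`, has not yet been measured. It differs from compound 2 by chloro in place of fluoro on an aromatic carbon. Within the data shown here, this is the same kind of change as the one from compound 1 to compound 3, but the surroundings differ: there the chloro sits meta to a group of 7 heavy atoms and para to a methylsulfonyl group, here meta to a methylsulfonyl group and para to a group of 7 heavy atoms.

From compound 2 to compound 4 a step of a 1.5-fold lower number from compound 2 to compound 4 (0.17 log units; within the scatter) is expected, a guess that rests on the earlier step because a 1.5-fold lower number from compound 1 to compound 3 (0.18 log units; within the scatter) stayed within the scatter. Compound 4 is therefore estimated at 450 nM in this assay, most likely between 200 nM and 1000 nM.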

Compound 4, inhibition constant: 457 nM
The estimate for compound 4 lay 1.0-fold (0.01 log units) below the measured number; measured number inside the range.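

In this assay, putting chloro in place of fluoro on the second core gave a 1.4-fold lower number from compound 2 to compound 4 (0.16 log units; within the scatter). The same change has now been read on two cores, and the two steps agree: the same change on two cores in this assay, a 1.5-fold lower number (0.18 log units; within the scatter) from compound 1 to compound 3 and a 1.4-fold lower number (0.16 log units; within the scatter) from compound 2 to compound 4, 1.0-fold (0.02 log units) apart, within the scatter of two such steps

So the change carried over from one core to the other without a visible difference, even though the methylsulfonyl group and the group of 7 heavy atoms sit differently relative to the halogen. Each step is itself within the scatter, however, so this does not show that chloro and fluoro truly differ in this assay, nor that the change would behave the same way on any further core.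

The compounds shown carry only fluoro or chloro at this carbon, which leaves open what a bromo, methyl or methoxy group there would give. As far as these compounds go, they also all keep the methylsulfonyl group, so it remains open whether an amide or a carboxylic acid in its place would move the number beyond the scatter.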